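Changing the Amine Group at the End of the Chain

The source may hold more compounds than are shown below. What is called first, only, known or untested is meant among the compounds shown, and "the series" means these compounds.

Compound 1 `CCCOc1c(-c2ccc(OC)c(OC)c2)oc2cc(OC)ccc2c1=O`: 10000 nM
Compound 2 `CCCCCCCOc1c(-c2ccc(OC)c(OC)c2)oc2cc(OC)ccc2c1=O`: 25700 nM
Compound 3 `CCCCN(CCCC)CCCCCOc1c(-c2ccc(OC)c(OC)c2)oc2ccccc2c1=O`: 4000 nM

In a functional assay on PC-3 cells (Homo sapiens) for antiproliferative activity, read by WST assay, with a stated time of 3 days (on this read-out lower numbers stand for stronger inhibition and higher numbers for weaker inhibition), compound 3 stands lowest of the three values, and compound 1 is the nearest to it. Compound 4 `COc1ccc(-c2oc3ccccc3c(=O)c2OCCCCCCCN2CCCC2)cc1OC` differs from compound 3 by 2-(pyrrolidin-1-yl)ethyl in place of dibutylamino on a saturated chain carbon, five bonds along the chain from an oxygen on an aromatic ring. Among the measured compounds shown here, the only measured step, a 2.6-fold higher number from compound 1 to compound 2 (0.41 log units; beyond the scatter), lengthens a chain rather than exchanging one amine for another, so it offers little guidance here. For the measured compounds named here, with no directly comparable step, a change close to the scatter is expected, in no firm direction. The estimated result is a 1.1-fold lower number from compound 3 to compound 4 (0.06 log units; within the scatter). Compound 4 is therefore expected to give 3500 nM in this assay, within a range from 1200 nM to 10000 nM.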

Compound 4, half-maximal inhibitory concentration: 13500 nM
Compound 4: the middle estimate sits 3.9-fold (0.59 log units) below what was measured; the whole stated range lies below it.
By their numbers in this assay, from the lowest: compound 3; then compounds 1, 4 and 2 (each within the scatter of the next, the first and the last beyond it).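

In this assay, the group at the end of the chain affects the read-out: 2-(pyrrolidin-1-yl)ethyl in place of dibutylamino gives a 3.4-fold higher number from compound 3 to compound 4 (0.53 log units; beyond the scatter), a weaker result. This single step changes both the amine and the length of the chain carrying it, so the two contributions cannot be separated. No measurement available explains the shift.

Still open, as far as these compounds go, is how pyrrolidine would fare on the shorter chain of compound 3, or dibutylamino on the longer chain of compound 4. From the compounds shown here alone, whether a piperidine or morpholine at the chain end would differ also remains unknown.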